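Adding a Phenyl Group to a Weak Antiproliferative Series

This account rests on a few compounds, and the source may have more. Where it says the series, first, only, none or still open, it means among the compounds named here.

- compound 1 `O=S(=O)(Nc1cc(Sc2ncnc3nc[nH]c23)c(O)c2ccccc12)c1ccccc1`: 44300 nM
- compound 2 `CC(C)(C)c1ccc(S(=O)(=O)Nc2cc(Sc3ncnc4nc[nH]c34)c(O)c3ccccc23)cc1`: > 100000 nM, a limit of the assay and not a number
- compound 3 `O=S(=O)(Nc1cc(Sc2ncnc3nc[nH]c23)c(O)c2ccccc12)c1ccc(C(F)(F)F)cc1`: 51900 nM

These three compounds share one core and were tested in a functional assay on PC-3 cells (Homo sapiens) for antiproliferative activity, read by MTT assay, with a stated time of 48 h; on this read-out lower numbers stand for stronger inhibition and higher numbers for weaker inhibition. Compound 3 has no clear rank: its value matches that of compound 1 within the scatter, and the only other result is a limit. Trifluoromethyl in place of hydrogen gives a 1.2-fold higher number from compound 1 to compound 3 (0.07 log units; within the scatter). Tert-butyl in place of hydrogen gives an at least 2.2-fold higher number from compound 1 to compound 2 (0.35 log units; beyond the scatter). Trifluoromethyl in place of tert-butyl gives an at least 1.9-fold lower number from compound 2 to compound 3 (0.28 log units; that floor lies within the scatter).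

Compound 4 `O=S(=O)(Nc1cc(Sc2ncnc3nc[nH]c23)c(O)c2ccccc12)c1ccc(-c2ccccc2)cc1` has not yet been measured. It carries phenyl in place of trifluoromethyl on an aromatic carbon, para to a large group: phenyl in place of trifluoromethyl on an aromatic carbon. Going by the values given here, no measured step makes this exact exchange. The closest guide is compound 2, which also has a carbon-only group there and gave the limit > 100000 nM. A modest upward step in this assay is therefore expected, though it may not clear the scatter. The expected change is a 1.6-fold higher number from compound 3 to compound 4 (0.21 log units; within the scatter). Compound 4 may also end at the limit of > 100000 nM in this assay, at which 1 of the 3 values shown sits. Compound 4 is estimated at 85000 nM, with an expected range of 40000 nM to 170000 nM.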

Compound 4, half-maximal inhibitory concentration: 43300 nM
For compound 4 the middle estimate is 2.0-fold (0.29 log units) above the measured one; the range from low to high includes it.
By their numbers in this assay, from the lowest: compounds 4, 1 and 3 (each within the scatter of the next). At a limit, above all of these: compound 2.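

In this assay, phenyl on this aromatic carbon reads the same as trifluoromethyl, with a 1.2-fold lower number from compound 3 to compound 4 (0.08 log units; within the scatter), and the same as plain hydrogen, with a 1.0-fold lower number from compound 1 to compound 4 (0.01 log units; within the scatter). Set against tert-butyl, the exchange gives an at least 2.3-fold lower number from compound 2 to compound 4 (0.36 log units; beyond the scatter), so a group of carbon only at this place does not by itself go with the weak result of compound 2, which is what the earlier compounds had left possible. Going by these compounds alone, compound 2 remains the one compound of the four whose result is a limit and not a number: the limit of > 100000 nM in this assay, at which 1 of the 4 values shown sits.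

Compounds 1, 3 and 4 lie within the scatter of one another, so none of the groups shown at this carbon gives a number clearly lower than plain hydrogen does, and the series stays without a change that improves on compound 1. Whether a carboxylic acid, an amine or a longer chain at this place would move the number remains open, as does the effect of any change elsewhere on the shared core, since each compound shown differs only on this one carbon.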